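A few compounds are considered here, and "the series" means these few. Any claim that something is new, unique, unknown or untested is made for them only; others in the source may bear on it.

Measured so far:
compound 1, `COc1ccc2c(c1)OC(OC)(c1ccccc1)C(O)(O)C2=O`: in a functional assay on KB cells (Homo sapiens) for cytotoxicity (on this read-out higher numbers stand for an effect only at larger amounts of compound and lower numbers for an effect already at smaller amounts), compound 1 gives 20 ug/mL;
compound 2, `COc1ccc(C2(OC)Oc3cc(OC)ccc3C(=O)C2(O)O)cc1`: compound 2 gives 2.8 ug/mL;
compound 3, `COc1cc(OC)cc(-c2cc(=O)c3c(OC)c(OC)c(OC)c(OC)c3o2)c1`: compound 3 gives 3 ug/mL.

Compound 4, `COc1cc(-c2cc(=O)c3c(OC)c(OC)c(OC)c(OC)c3o2)cc(OC)c1OC`, has not been measured. Compound 2 differs from compound 1 by methoxy in place of hydrogen on an aromatic carbon, and that change made a 7.1-fold lower number from compound 1 to compound 2 (0.85 log units; beyond the scatter). Compound 4 differs from compound 3 by methoxy in place of hydrogen on an aromatic carbon, the same kind of change; the place in compound 4 is also ortho to two methoxy groups, which the place in compound 2 is not. How the core of compound 3 differs from the core of compound 1 is not broken down here. Compound 2 and compound 3 give numbers within the usual scatter of each other. For compound 4 in this assay a smaller step than the earlier one is expected, a 2.0-fold lower number from compound 3 to compound 4 (0.30 log units; within the scatter), because the earlier step of a 7.1-fold lower number from compound 1 to compound 2 (0.85 log units; beyond the scatter) was measured on a different core and the surroundings of the place are not the same. Compound 4 is therefore expected to give about 1.5 ug/mL, most likely between 0.5 ug/mL and 5 ug/mL.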

Compound 4, concentration for half-maximal effect: 0.5 ug/mL
For compound 4 the middle estimate is 3.0-fold (0.48 log units) above the measured one; the range from low to high includes it.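

In this assay, methoxy in place of hydrogen on an aromatic carbon gave a 6.0-fold lower number from compound 3 to compound 4 (0.78 log units; beyond the scatter), and this step matches the earlier one on a different core: the same change on two cores in this assay, a 7.1-fold lower number (0.85 log units; beyond the scatter) from compound 1 to compound 2 and a 6.0-fold lower number (0.78 log units; beyond the scatter) from compound 3 to compound 4, 1.2-fold (0.08 log units) apart, within the scatter of two such steps So, in these two pairs, the change carried over in both direction and size, even though the place in compound 4 is ortho to two methoxy groups and the place in compound 2 is not. Two pairs are still only two cases, so they do not show that the step would hold on further cores, and they do not explain why the number falls.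

As far as these compounds go, it remains open whether an ethoxy, a longer chain, an amine or a carboxylic acid at the same place would give a similar step.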